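A few compounds are considered here, and "the series" means these few. Any claim that something is new, unique, unknown or untested is made for them only; others in the source may bear on it.

Measured in an ADME assay (liver) for pharmacokinetics, with Liver microsome (Rattus norvegicus) as the target, using microsomes; a lower number here means that the compound disappears faster, a higher number that the compound lasts longer:
- compound 1 `CCCCCCOC(=O)/C=C/c1ccc(NC(=O)C2(NC(=O)c3ccc4c(C5CCCC5)c(-c5ncc(Cl)cn5)n(C)c4c3)CCC2)cc1OCC` gives 12.7 h
- compound 2 `CCOc1cc(NC(=O)C2(NC(=O)c3ccc4c(C5CCCC5)c(-c5ncc(Cl)cn5)n(C)c4c3)CCC2)ccc1/C=C/C(=O)OCCOCCOC` gives 1.07 h

Going by the values given here, compound 2 stands lowest of the two numbers in this assay; the one measured step, a 12-fold lower number from compound 1 to compound 2 (1.07 log units; beyond the scatter), reached it. Compound 3 `CCOc1cc(NC(=O)C2(NC(=O)c3ccc4c(C5CCCC5)c(-c5ncc(Cl)cn5)n(C)c4c3)CCC2)ccc1/C=C/C(=O)OCC(=O)OCc1ccc(Cl)cc1` is not yet measured. It differs from compound 2 in one place: ((4-chlorobenzyl)oxy)carbonyl in place of (2-methoxyethoxy)methyl on a saturated chain carbon bound to an oxygen next to a carbonyl group. Among the compounds with values here, only that one step bears on this change, and it was large, so a step beyond the scatter seems possible, plausibly upward because the motif that entered in a 12-fold lower number from compound 1 to compound 2 (1.07 log units; beyond the scatter) now leaves. The half-life of compound 3 in this assay is therefore estimated at 2.5 h, ranging from 0.6 h to 10 h, a step of a 2.3-fold higher number from compound 2 to compound 3 (0.37 log units; beyond the scatter).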

Compound 3, half-life: 11.4 h
Compound 3: middle estimate off by 4.6-fold (0.66 log units), on the low side, and the stated range ends below it.
By their numbers in this assay, from the lowest: compound 2; then compounds 3 and 1 (each within the scatter of the next).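

In this assay, placing ((4-chlorobenzyl)oxy)carbonyl where (2-methoxyethoxy)methyl stood gives an 11-fold higher number from compound 2 to compound 3 (1.03 log units; beyond the scatter) on a saturated chain carbon bound to an oxygen next to a carbonyl group, although both groups carry the same count of hydrogen-bond acceptors. Set against pentyl, the same group gives a 1.1-fold lower number from compound 1 to compound 3 (0.05 log units; within the scatter) at this place, so a low half-life does not follow from every replacement of the plain chain. Nothing available explains this difference. From the compounds shown here alone, whether the chlorine, the aromatic ring or the carbonyl matters remains open, as does how an amine or a carboxylic acid would fare on this chain.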